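Benzyl for ethyl on the piperidine of compound 3

A few compounds are considered here, and "the series" means these few. Any claim that something is new, unique, unknown or untested is made for them only; others in the source may bear on it.

Compound 1 `CC(C(=O)NCc1ccc(C(C)(C)C)nc1N1CCCC1)c1ccc(NS(C)(=O)=O)c(F)c1`: 1.2 nM
Compound 2 `CC(C(=O)NCc1ccc(C(C)(C)C)nc1N1CCCCCC1)c1ccc(NS(C)(=O)=O)c(F)c1`: 0.9 nM
Compound 3 `CCC1CCN(c2nc(C(C)(C)C)ccc2CNC(=O)C(C)c2ccc(NS(C)(=O)=O)c(F)c2)CC1`: 0.1 nM

Three measured compounds share one core and differ only in the saturated nitrogen ring attached to the aromatic carbon. In an assay on cells for antagonist activity at transient receptor potential cation channel subfamily V member 1 (Homo sapiens), read by FLIPR and calcium flux, with a stated time of 6 min (on this read-out lower numbers stand for stronger inhibition and higher numbers for weaker inhibition), compound 3 holds the lowest number of the three, and both of its steps lie beyond the scatter: a 12-fold lower number from compound 1 to compound 3 (1.08 log units; beyond the scatter) and a 9.0-fold lower number from compound 2 to compound 3 (0.95 log units; beyond the scatter). Between the other two, a 1.3-fold lower number from compound 1 to compound 2 (0.12 log units; within the scatter), which is within the scatter.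

Compound 4 `CC(C(=O)NCc1ccc(C(C)(C)C)nc1N1CCC(Cc2ccccc2)CC1)c1ccc(NS(C)(=O)=O)c(F)c1` keeps the piperidine of compound 3 and changes only its substituent: phenyl in place of methyl on a saturated chain carbon bound to a saturated ring carbon. For the measured compounds named here, no measured step touches this substituent; the two steps that end at compound 3 both exchange the whole ring, and the one that does not involve compound 3 is within the scatter. Going by the values given here, there is therefore no measured step that bears directly on the change from compound 3 to compound 4, and the expectation rests on compound 3 alone.

On that footing, compound 4 is expected to stay close to compound 3, with an estimated step of a 1.5-fold higher number from compound 3 to compound 4 (0.18 log units; within the scatter), not beyond the scatter. The estimate for compound 4 in this assay is 0.15 nM, with a range from 0.04 nM to 0.6 nM.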

Compound 4, inhibition constant: 0.3 nM
The estimate for compound 4 lay 2.0-fold (0.30 log units) below the measured number; measured number inside the range.
By their numbers in this assay, from the lowest: compound 3; then compound 4; then compounds 2 and 1 (each within the scatter of the next).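

The earlier compounds exchanged only the whole ring, whereas compound 4 is the first shown to change the substituent on the piperidine alone, and in this assay this substituent proves to matter: there is a 3.0-fold higher number from compound 3 to compound 4 (0.48 log units; beyond the scatter). Ethyl therefore remains the better of the two substituents, but benzyl is accepted at this place without the number rising to the level of the other rings, since compound 4 at 0.3 nM still carries a lower number than compound 2 at 0.9 nM. Nothing shown here gives a reason for the size of this step.

The compounds shown leave open whether the step follows from the aromatic ring of the benzyl group or simply from the added carbons, a question that a cyclohexylmethyl group or a longer chain such as butyl at this place would help to separate. They also leave open how the number would respond to an amine or a carboxylic acid on the benzyl ring.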